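The source may report more compounds than this note shows. Statements on the series, on what has been measured and on what is new or still open speak of the compounds shown alone.

Working notes on the series, cytotoxicity.

Compound 2 `Cc1cc(/C=C2\S/C(=N\c3ccccc3)N(C3CCCCC3)C2=O)c(C)[nH]1` carries a free ring nitrogen-hydrogen on the five-membered ring. In an ADME assay on L6 cells (Rattus norvegicus) for cytotoxicity, read by microscopy and resazurin assay, with a stated time of 72 h (on this read-out lower numbers stand for an effect already at smaller amounts and higher numbers for an effect only at larger amounts of compound), compound 2 gives 23000 nM. Within the data shown here, that is the only number so far in this assay; the other value is a limit. Compound 1 `Cc1cc(/C=C2\S/C(=N\c3ccccc3)N(C3CCCCC3)C2=O)c(C)n1-c1ccccc1C(F)(F)F` bears a 2-(trifluoromethyl)phenyl on that nitrogen, and in this assay compound 1 gives > 170000 nM, a limit of the assay and not a number, so that compound 1 sits at the limit of > 170000 nM in this assay, at which 1 of the 2 values shown sits. The measured step of an at least 7.3-fold lower number from compound 1 to compound 2 (0.86 log units; beyond the scatter) therefore shows that removing the large aryl group gives a markedly lower number.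

Compound 3 `Cc1cc(/C=C2\S/C(=N\c3ccccc3)N(C3CCCCC3)C2=O)c(C)n1C` is the next case: methyl in place of hydrogen on an aromatic nitrogen. Among the measured compounds shown here, the only measured step, from compound 1 to compound 2, concerns a much larger group than methyl, so it bears on this change only loosely. A methyl is a single carbon; the effect of adding it is expected to be small, if anything a slight move back toward the higher numbers of compound 1. For compound 3 the expected step is a 1.3-fold higher number from compound 2 to compound 3 (0.12 log units; within the scatter), within the scatter. Compound 3 is estimated at 30000 nM in this assay, with a range of 12000 nM to 80000 nM.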

Compound 3, half-maximal effective concentration: > 230000 nM
Compound 3 was reported as a limit; the forecaster's own chance of this, stated with the estimate: 10%; middle value at least 7.6-fold (0.88 log units) away from the limit.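

On the aromatic nitrogen of the five-membered aromatic ring, methyl alone is enough to give a clear change in this assay: methyl in place of hydrogen produces an at least 10-fold higher number from compound 2 to compound 3 (1.00 log units; beyond the scatter). The higher number therefore does not belong only to the large 2-(trifluoromethyl)phenyl of compound 1: among the three compounds, compound 2 alone has a free ring nitrogen-hydrogen, and it alone has a readable number. Compound 1 and compound 3 both stand at limits of the assay and not at numbers, the step between them cannot be read, and so methyl and 2-(trifluoromethyl)phenyl cannot be ranked against each other.

Going by these compounds, how far the number rises with a substituent on this nitrogen remains open, since neither substituted compound has a readable value, and it is also unclear whether any replacement of the hydrogen gives the same outcome. An ethyl, or a longer chain ending in an amine or a carboxylic acid, on this nitrogen would test whether the change follows from losing the hydrogen or depends on the group that enters.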